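This account rests on a few compounds, and the source may have more. Where it says the series, first, only, none or still open, it means among the compounds named here.

Compound 1, `N#CCn1c2ccc([N+](=O)[O-])cc2c(=O)n1Cc1ccccc1`. In an ADME assay on L929 cells (Mus musculus) for cytotoxicity, read by resazurin assay, with a stated time of 48 h (on this read-out higher numbers stand for lower toxicity in this test and lower numbers for higher toxicity in this test), compound 1 gives > 256000 nM, which is a limit of the assay and not a number.
Compound 2, `NC(=O)CCCn1c2ccc([N+](=O)[O-])cc2c(=O)n1Cc1ccccc1`. In this assay compound 2 gives > 256000 nM, again a limit.
Compound 3, `O=c1c2cc([N+](=O)[O-])ccc2n(CCO)n1Cc1ccccc1`. In this assay compound 3 gives > 256000 nM, also a limit.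

Compound 3 thus stands at the same limit as the other two, and no value in the set is a number. The steps among them are a step that the two limits leave unreadable from compound 1 to compound 2, a step that the two limits leave unreadable from compound 1 to compound 3 and a step that the two limits leave unreadable from compound 2 to compound 3; their size cannot be read, since (the limit of > 256000 nM in this assay, at which 3 of the 3 values shown sit). The unmeasured compound 4, `Cc1ccc(S(=O)(=O)n2c3ccc([N+](=O)[O-])cc3c(=O)n2Cc2ccccc2)cc1`, differs from compound 3 by (4-methylphenyl)sulfonyl in place of 2-hydroxyethyl on an aromatic nitrogen. For the measured compounds named here, none of the three measured steps concerns this exchange, and none has a readable size, so they give no direction for the step. Given that every measured compound sits at the limit, compound 4 is expected to give 256000 nM, with a range from 100000 nM to 600000 nM. The expected step from compound 3 is a number no higher from compound 3 to compound 4 (the limit leaves the size open), an estimate that most likely ends at the limit again.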

Compound 4, concentration lethal to 50% of the cells: > 256000 nM
Compound 4: no number, only a limit; the forecaster's own chance of this, stated with the estimate: 70%; the middle value lies on the limit itself.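

In this assay compound 4 gives > 256000 nM, again a limit and not a number. Its steps from compound 1, compound 2 and compound 3 therefore cannot be read: the limit of > 256000 nM in this assay, at which 4 of the 4 values shown sit.

The compounds shown leave open whether the groups on the aromatic nitrogen differ at all in this assay.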